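The compounds below may be only part of what the source reports. "The series", "measured", "known", "first", "only" and "open" are said of these compounds alone.

Compound 1 `CSc1ncnc2c1c(-c1ccccc1)cn2[C@@H]1O[C@H](CO)[C@@H](O)[C@H]1O` — in a functional assay on A549 cells (Homo sapiens), read by MTT assay, with a stated time of 72 h (a lower number here means a stronger inhibitor, a higher number a weaker inhibitor), compound 1 gives > 20000 nM, which is a limit of the assay and not a number.
Compound 2 `Nc1nc(N)c2c(-c3ccccc3)cn([C@@H]3O[C@H](CO)[C@@H](O)[C@H]3O)c2n1` — in this assay compound 2 gives > 20000 nM, again a limit of the assay.
Compound 3 `CSc1ncnc2c1c(-c1cccs1)cn2[C@@H]1O[C@H](CO)[C@@H](O)[C@H]1O` — in this assay compound 3 gives > 20000 nM, also a limit of the assay.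

Compound 3 arises from compound 1 by one change, (thiophen-2-yl in place of phenyl on an aromatic carbon). The step that the two limits leave unreadable from compound 1 to compound 3 cannot be read, since both values are limits. The difference between the cores of compound 1 and compound 2 is not broken down here.

Compound 4 `Nc1nc(N)c2c(-c3cccs3)cn([C@@H]3O[C@H](CO)[C@@H](O)[C@H]3O)c2n1` is the compound still to be measured. It arises from compound 2 by the same change, (thiophen-2-yl in place of phenyl on an aromatic carbon), made at the same place as described for compound 1 and compound 3.

Among the measured compounds shown here, the expectation for compound 4 rests on the limit of > 20000 nM in this assay, at which 3 of the 3 values shown sit: every value so far sits at that limit, and the one measured instance of this change, from compound 1 to compound 3, left the value there. For compound 4 the step that the limit leaves unreadable from compound 2 to compound 4 is therefore expected to be essentially nil. Compound 4 is expected to give about 25000 nM in this assay, estimated between 10000 nM and 80000 nM, most likely again reported only as a limit.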

Compound 4, half-maximal inhibitory concentration: > 20000 nM
Compound 4 was reported as a limit (the forecaster's own chance of this, stated with the estimate: 85%); the middle value does not contradict the limit.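

Compound 4 gives > 20000 nM in this assay, a limit of the assay and not a number. Compound 2 also sits at a limit, so the change from phenyl to thiophen-2-yl between compound 2 and compound 4 gives no readable step. The compounds shown leave open whether this change affects activity at all, with every result at one limit: the limit of > 20000 nM in this assay, at which 4 of the 4 values shown sit.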